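Amide Aryl Swap on a Shared Core

The compounds below may be only part of what the source reports. "The series", "measured", "known", "first", "only" and "open" are said of these compounds alone.

Of the compounds shown here, two sharing one core have been measured so far. Compound 1 `COc1ccccc1C(=O)Nc1cccc(-c2oc3cc(-c4ccc(F)cc4)ccc3c(=O)c2O)c1` was tested in a functional assay on HepG2 cells (Homo sapiens) for antiproliferative activity, read by CCK-8 assay, with a stated time of 72 h (a lower number here means a stronger inhibitor, a higher number a weaker inhibitor), and gives 14500 nM. Compound 2 `COc1cc(OC)cc(C(=O)Nc2cccc(-c3oc4cc(-c5ccc(F)cc5)ccc4c(=O)c3O)c2)c1` gives 23500 nM. Among the compounds with values here, the only step between measured compounds, a 1.6-fold higher number from compound 1 to compound 2 (0.21 log units; within the scatter), is within the scatter, so the two numbers cannot be told apart, and no third measured compound exists to place compound 2 against.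

Compound 3 `O=C(Nc1cccc(-c2oc3cc(-c4ccc(F)cc4)ccc3c(=O)c2O)c1)c1ccc([N+](=O)[O-])cc1` is not yet measured. It differs from compound 2 in one place: 4-nitrophenyl in place of 3,5-dimethoxyphenyl on a carbonyl carbon. Within the data shown here, no measured step bears directly on this change. Among the measured compounds shown here, the one step seen, from 2-methoxyphenyl to 3,5-dimethoxyphenyl, was within the scatter, which says only that altering the methoxy pattern on that ring left the number about where it was. A nitrophenyl in that position is a different kind of change, and nothing measured shows what it does. The expected step from compound 2 to compound 3 is therefore a 1.3-fold lower number from compound 2 to compound 3 (0.12 log units; within the scatter), with no clear direction and a wide uncertainty. Compound 3 is estimated at 18000 nM, with a range from 5000 nM to 60000 nM.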

Compound 3, half-maximal inhibitory concentration: 1860 nM
Compound 3: the middle estimate sits 9.7-fold (0.99 log units) above what was measured; the measured number lies below the stated range.
By their numbers in this assay, from the lowest: compound 3; then compounds 1 and 2 (each within the scatter of the next).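

In this assay, the aryl group on this carbonyl carbon proves able to move the number well beyond the scatter: 4-nitrophenyl gives a 13-fold lower number from compound 2 to compound 3 (1.10 log units; beyond the scatter) and a 7.8-fold lower number from compound 1 to compound 3 (0.89 log units; beyond the scatter). The earlier pair, with its two methoxy-bearing rings, gave numbers that could not be told apart, so it could not show whether this position responds to a change at all; compound 3 shows that it does, and the response appears against both methoxy-bearing rings. The 3,5-dimethoxyphenyl and 4-nitrophenyl groups have the same counts of hydrogen-bond donors and acceptors, but nothing here explains why the number falls.

Only one nitro-bearing ring appears among these compounds, so it remains open whether the lower number belongs to the nitro group itself, to its place on the ring, or to the loss of the methoxy groups. An unsubstituted phenyl on the same carbonyl carbon, or a ring carrying a nitrile, an amine or a carboxylic acid in place of the nitro group, would help separate these possibilities.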